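An Ethyl Group on the Chain Carbon at the Nitrogen

A few compounds are considered here, and "the series" means these few. Any claim that something is new, unique, unknown or untested is made for them only; others in the source may bear on it.

compound 1 `CCCCC[C@H](CN(O)C=O)C(=O)NCNC(=O)c1cc2cccc(OC)c2o1`: 160 nM
compound 2 `COc1cccc2cc(C(=O)NCNC(=O)[C@H](Cc3ccccc3)CN(O)C=O)oc12`: 160 nM

In an assay on CHO cells for inhibition of bone morphogenetic protein 1 (Homo sapiens), with stated times of 10 min and 60 min (a lower number here means a stronger inhibitor, a higher number a weaker inhibitor), compound 1 gives 160 nM and compound 2 gives 160 nM. Among the measured compounds shown here, the one step measured, no change at the digits printed from compound 1 to compound 2 (within the scatter), touches a different part of the molecule. Compound 3 `CCCCC[C@@H](C(=O)NCNC(=O)c1cc2cccc(OC)c2o1)[C@H](CC)N(O)C=O` differs from compound 1 as follows: ethyl in place of hydrogen on a saturated chain carbon bound to an amide-type nitrogen and a saturated chain carbon. For the measured compounds named here, no measured step bears on this change, so the expectation rests on compound 1 alone; a step of a 1.6-fold higher number from compound 1 to compound 3 (0.19 log units; within the scatter) in this assay is expected, with wide uncertainty in either direction. Compound 3 is therefore estimated at 250 nM, within 60 nM to 1500 nM.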

Compound 3, half-maximal inhibitory concentration: > 10000 nM
Compound 3: no number, only a limit (the forecaster's own chance of this, stated with the estimate: 5%); middle value at least 40-fold (1.60 log units) from the limit.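

In this assay, among the compounds shown here, ethyl in place of hydrogen on this saturated chain carbon bound to an amide-type nitrogen and a saturated chain carbon gives an at least 62-fold higher number from compound 1 to compound 3 (1.79 log units; beyond the scatter), whereas the one earlier change, at another place, gave no change at the digits printed from compound 1 to compound 2 (within the scatter). Compound 3 stands at > 10000 nM, which is a limit of the assay and not a number. This position is thus the first shown where a single change costs activity beyond the scatter. The compounds shown leave open whether a methyl group on this carbon would fare better, and whether ethyl here would cost as much in compound 2.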